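The source may hold more compounds than are shown below. What is called first, only, known or untested is meant among the compounds shown, and "the series" means these compounds.

Working notes on the series. In an ADME assay on BaF3 cells (Mus musculus) for antiproliferative activity, read by CCK-8 assay, with a stated time of 72 h (a lower number here means a stronger inhibitor of growth, a higher number a weaker inhibitor of growth), compound 1 `O=C(CCSc1ccc2c(/C=C/c3ccccn3)n[nH]c2c1)Nc1ccccc1` gives 690 nM. Compound 2 `Cc1cccc(NC(=O)CCSc2ccc3c(/C=C/c4ccccn4)n[nH]c3c2)c1` carries one extra methyl; in this assay compound 2 gives > 10000 nM, which is a limit of the assay rather than a number (the limit of > 10000 nM in this assay, at which 1 of the 3 values shown sits). The step of an at least 14-fold higher number from compound 1 to compound 2 (1.16 log units; beyond the scatter) therefore reads as a marked loss of growth inhibition, with the change being (methyl in place of hydrogen on an aromatic carbon).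

Compound 3 `CN1CCN(Cc2ccc(NC(=O)CCSc3ccc4c(-c5cccnc5)n[nH]c4c3)cc2C(F)(F)F)CC1` has a different core; the difference between the two cores is not broken down here. In this assay compound 3 gives 2650 nM.

Compound 4 `Cc1ccc(-c2n[nH]c3cc(SCCC(=O)Nc4ccc(CN5CCN(C)CC5)c(C(F)(F)F)c4)ccc23)cn1` is not yet measured. It differs from compound 3 by methyl in place of hydrogen on an aromatic carbon, the same kind of change as from compound 1 to compound 2, but at another place: the ring is a six-membered aromatic ring with 1 nitrogen, the methyl sits next to the ring nitrogen and para to a large group, whereas in compound 2 it is on a ring of carbon only, meta to a large group. Given the loss seen in an at least 14-fold higher number from compound 1 to compound 2 (1.16 log units; beyond the scatter), a weakening step is expected, a 2.3-fold higher number from compound 3 to compound 4 (0.35 log units; beyond the scatter), though the different place leaves the size uncertain. For compound 4 in this assay a value of about 6000 nM is estimated, within 1500 nM to 25000 nM.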

Compound 4, concentration for 50% growth inhibition: 1180 nM
For compound 4 the middle estimate is 5.1-fold (0.71 log units) above the measured one, outside the stated range (below it).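

In this assay the change from pyridin-3-yl to 6-methylpyridin-3-yl gives a 2.2-fold lower number from compound 3 to compound 4 (0.35 log units; beyond the scatter), so methyl in place of hydrogen on an aromatic carbon does not carry one direction of effect from one core to the other: the same change on two cores in this assay, an at least 14-fold higher number (1.16 log units; beyond the scatter) from compound 1 to compound 2 and a 2.2-fold lower number (0.35 log units; beyond the scatter) from compound 3 to compound 4, at least 32-fold (1.51 log units) apart, beyond the scatter of two such steps

Compound 2 stands at > 10000 nM, which is a limit of the assay.

The two steps differ in the core and also in the ring and place that carry the methyl, so this pair does not show whether the core, the ring or the place sets the outcome.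

Still open, on these data alone, is whether a methyl on the carbon-only ring, at the place it holds in compound 2, would give the same result on the core of compound 3, which would separate the core from the place. Also open, as far as these compounds go, is whether a methoxy, an ethyl or an amine on the carbon that carries the methyl in compound 4 would follow the same direction as that methyl.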